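Swapping an aryl imine for an acetamido hydrazone

The source may report more compounds than this note shows. Statements on the series, on what has been measured and on what is new or still open speak of the compounds shown alone.

Measured compounds:
Compound 1 `O=C1Nc2ccc(S(=O)(=O)N3CCOCC3)cc2/C1=N/c1cccc(C(F)(F)F)c1`: in a functional assay on MCF7 cells (Homo sapiens) for cytotoxicity, read by sulforhodamine B assay, with a stated time of 24 h (on this read-out higher numbers stand for weaker inhibition and lower numbers for stronger inhibition), compound 1 gives 41100 nM.
Compound 2 `O=C1Nc2ccc(S(=O)(=O)N3CCOCC3)cc2/C1=N/c1ccc(/N=C2\C(=O)Nc3ccc(S(=O)(=O)N4CCOCC4)cc32)cc1`: in this assay compound 2 gives 10900 nM.

Of the two numbers shown, compound 1 stands highest, which on this read-out means the weakest inhibition of the pair; compound 2 sits lower, and the gap between them lies beyond the usual scatter. Among the measured compounds shown here, no pair of measured compounds differing in a single place is available, so no measured step can guide the next change directly.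

Compound 3 `CC(=O)N/N=C1\C(=O)Nc2ccc(S(=O)(=O)N3CCOCC3)cc21` differs from compound 1 in one place: acetamido in place of 3-(trifluoromethyl)phenyl on a double-bonded nitrogen. The two measured compounds give no reading on what an acetamido group brings where a 3-(trifluoromethyl)phenyl group stood, so the expectation rests on compound 1 alone. The step is expected to be modest, a 1.3-fold higher number from compound 1 to compound 3 (0.13 log units; within the scatter), toward a somewhat higher number, close to the edge of the scatter rather than clearly beyond it. Compound 3 is therefore estimated at 55000 nM, with a range from 15000 nM to 200000 nM.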

Compound 3, half-maximal inhibitory concentration: 56000 nM
Beside the measured number, compound 3's estimate is 1.0-fold (0.01 log units) below it, within the range that was stated.
By their numbers in this assay, from the lowest: compound 2; then compounds 1 and 3 (each within the scatter of the next).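

In this assay, acetamido in place of 3-(trifluoromethyl)phenyl on a double-bonded nitrogen gives a 1.4-fold higher number from compound 1 to compound 3 (0.13 log units; within the scatter) and so leaves the two compounds within the scatter of each other. At this position, then, a group of 10 heavy atoms with a six-membered aromatic ring of carbon only and an open group of 4 heavy atoms with a hydrogen-bond donor and acceptor read alike, which shows that the aromatic ring is not required to hold the number at this level in this pair. Nothing measured here explains why these two groups read alike.

On these data alone, whether other groups on this nitrogen also read alike stays open, for instance a simple amine, a longer carbon chain or a carboxylic acid, any of which could show whether the position responds at all in this assay. Compound 2, at 10900 nM, differs from compound 3 in more than one place, so no single change connects them and the source of its number remains unresolved.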